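The compounds below may be only part of what the source reports. "The series", "measured", "known", "first", "only" and "open" are said of these compounds alone.

Among the measured compounds shown here, in a functional assay on T98G cells (Homo sapiens) for inhibition, read by MTT assay, with a stated time of 72 h (on this read-out lower numbers stand for stronger inhibition and higher numbers for weaker inhibition), two compounds have numbers so far. Compound 1 `CC1(C)CC(NC(=S)Nc2ccc(C#N)cc2)c2cc(F)ccc2O1` gives 19000 nM, and compound 2 `COc1cccc(NC(=S)NC2CC(C)(C)Oc3ccc(Br)cc32)c1` gives 87000 nM. Compound 2 therefore holds the higher of the two numbers, meaning weaker inhibition, and the gap lies beyond the usual scatter. Compound 3 `CC1(C)CC(NC(=S)Nc2ccc(C#N)cc2)c2cc(Br)ccc2O1` is still unmeasured. It follows from compound 2 through (4-cyanophenyl in place of 3-methoxyphenyl on an amide-type nitrogen), with 4-cyanophenyl in place of 3-methoxyphenyl on an amide-type nitrogen. For the measured compounds named here, no measured pair differs in one place only, so the evidence is indirect. Compound 1 also carries 4-cyanophenyl and gives 19000 nM, which points to a lower number for the new compound. The expected change, a 4.4-fold lower number from compound 2 to compound 3 (0.64 log units; beyond the scatter), is a fall beyond the scatter, towards stronger inhibition. For compound 3 the estimated value is 20000 nM, with an expected range from 8000 nM to 50000 nM.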

Compound 3, half-maximal inhibitory concentration: 24000 nM
The estimate for compound 3 lay 1.2-fold (0.08 log units) below the measured number; the range from low to high includes it.
By their numbers in this assay, from the lowest: compounds 1 and 3 (each within the scatter of the next); then compound 2.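

Among the compounds shown here, putting 4-cyanophenyl in place of 3-methoxyphenyl on an amide-type nitrogen gives a 3.6-fold lower number from compound 2 to compound 3 (0.56 log units; beyond the scatter) in this assay and so places this change on a direct comparison for the first time, with only that group differing and bromo held on the shared core. With 4-cyanophenyl held, bromo in place of fluoro on an aromatic carbon gives a 1.3-fold higher number from compound 1 to compound 3 (0.10 log units; within the scatter) and so does not separate these two halogens in this assay. Nothing measured here accounts for either result.

Going by these compounds, the step on the nitrogen rests on a single pair, so whether it carries over to the fluoro series remains open. Also open, on these data alone, is how an aminophenyl or a carboxyphenyl group would read on that nitrogen, or a hydrogen in place of the halogen on the core.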